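The source may hold more compounds than are shown below. What is called first, only, known or untested is meant among the compounds shown, and "the series" means these compounds.

Two compounds of the series carry numbers in a functional assay on U-87MG ATCC cells for antiproliferative activity against U-87 MG (Homo sapiens), read by MTT assay, with a stated time of 48 h, tested at 100 uM; on this read-out higher numbers stand for a weaker effect at the one concentration tested and lower numbers for a stronger effect. Compound 1 `Cc1nc(-c2ccccc2)sc1C(=O)CSc1nc(-c2ccc(Cl)c(Cl)c2)c(C#N)c(=O)[nH]1` gives 24.4%, and compound 2 `Cc1nc(-c2ccccc2)sc1C(=O)CSc1nc(-c2cccc(Cl)c2)c(C#N)c(=O)[nH]1` gives 10%. Within the data shown here, the single step between them, a number 14.4 percentage points lower from compound 1 to compound 2 (beyond the scatter), leaves compound 2 with the lowest of the two numbers, the nearest being compound 1. Compound 3 `Cc1nc(-c2ccccc2)sc1C(=O)CSc1nc(-c2ccc(Cl)cc2)c(C#N)c(=O)[nH]1` is not yet measured; it differs from compound 2 by 4-chlorophenyl in place of 3-chlorophenyl on an aromatic carbon. Among the measured compounds shown here, no measured step swaps the chloro between these two groups, so the one known step bears only indirectly: it shows that a single change of chloro on this phenyl can move the read-out by a modest amount, with no sign of the direction for the present swap. A modest step of either sign, or none beyond the scatter, is therefore expected, a number 7 percentage points higher from compound 2 to compound 3 (within the scatter). For compound 3 the estimate in this assay is 17%, within 5% to 35%.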

Compound 3, a percentage reported as activity, at one concentration (the size of the read-out at that concentration, not a potency): 22.5%
Compound 3: middle estimate off by 5.5 percentage points, on the low side, within the range that was stated.
By their numbers in this assay, from the lowest: compound 2; then compounds 3 and 1 (each within the scatter of the next).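

In this assay, the chloro's place on the phenyl now counts on its own: with the same atoms, 4-chlorophenyl in place of 3-chlorophenyl gives a number 12.5 percentage points higher from compound 2 to compound 3 (beyond the scatter). Taking one chloro from compound 1 has two different outcomes, since the change that leaves 4-chlorophenyl gives a number 1.9 percentage points lower from compound 1 to compound 3 (within the scatter), while the one that leaves 3-chlorophenyl gives a number 14.4 percentage points lower from compound 1 to compound 2 (beyond the scatter); among these compounds, only compound 2 stands apart. No measurement to hand accounts for this difference between the two chloro placements.

Still open, as far as these compounds go, is how an unsubstituted phenyl, a 2-chlorophenyl or a methoxyphenyl would read at this place on the shared core. With a single concentration and one cell line, these numbers also leave open whether the order of compound 2 against the others holds at other concentrations.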